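A Nitrooxy Group Added to a Second Core

The source may hold more compounds than are shown below. What is called first, only, known or untested is meant among the compounds shown, and "the series" means these compounds.

Measured so far in a functional assay on the whole organism (strain Sprague-Dawley) for inhibition, with Rattus norvegicus as the target, read by paw edema, with stated times of 30 min and 1 h, at a dose of 80 mg/kg by the oral route; a higher number here means more inhibition at the dose given (going by the name of the read-out), a lower number less inhibition:
- compound 1 `O=c1c2ccccc2nc(CO[N+](=O)[O-])n1NS(=O)(=O)c1ccccc1` gives 2.4%
- compound 2 `Cc1nc2ccccc2c(=O)n1NS(=O)(=O)c1ccccc1` gives 5.6%
- compound 3 `Cc1nc2ccccc2c(=O)n1NC(=O)NC(C)(C)C` gives 10.4%

Compound 2 and compound 1 share a core and differ in one place: nitrooxy in place of hydrogen on a saturated chain carbon bound to an aromatic carbon. That change made a number 3.2 percentage points lower from compound 2 to compound 1 (within the scatter), so the two numbers cannot be told apart. Compound 3 carries a different core; the difference between the two cores is not broken down here. Compound 4 `CC(C)(C)NC(=O)Nn1c(CO[N+](=O)[O-])nc2ccccc2c1=O` is compound 3 with the same change applied: nitrooxy in place of hydrogen on a saturated chain carbon bound to an aromatic carbon, at the same place as before. Since the earlier step from compound 2 to compound 1 was a number 3.2 percentage points lower from compound 2 to compound 1 (within the scatter), the step from compound 3 to compound 4 is also expected to be small, estimated as a number 3.4 percentage points lower from compound 3 to compound 4 (within the scatter), because of a number 3.2 percentage points lower from compound 2 to compound 1 (within the scatter). Compound 4 is therefore expected to give about 7%, with a likely range from 0% to 17%.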

Compound 4, a percentage reported as inhibition, in the whole organism at one dose (the size of the read-out at that dose, not a potency): 6.4%
Beside the measured number, compound 4's estimate is 0.6 percentage points above it; the measured number falls inside the stated range.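

In this assay, putting nitrooxy in place of hydrogen on the second core gives a number 4 percentage points lower from compound 3 to compound 4 (within the scatter), so on this core too the change leaves no effect that can be told from scatter. This does not prove that the change does nothing, only that any effect is too small to detect here, and two cores cannot speak for every core in the series. As far as these numbers can tell, the change carries over from one core to the other without a visible difference: the same change on two cores in this assay, a number 3.2 percentage points lower (within the scatter) from compound 2 to compound 1 and a number 4 percentage points lower (within the scatter) from compound 3 to compound 4, 0.8 percentage points apart, within the scatter of two such steps

The compounds shown leave open whether a different group on the same carbon, such as an amine or a carboxylic acid, would move the number beyond the scatter. They also leave open whether a longer chain carrying the nitrooxy group would do so.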